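A few compounds are considered here, and "the series" means these few. Any claim that something is new, unique, unknown or untested is made for them only; others in the source may bear on it.

Measured so far in an assay on SK-BR-3 cells for inhibition of Aromatase (Homo sapiens); on this read-out higher numbers stand for weaker inhibition and lower numbers for stronger inhibition:
compound 1, `CCCOc1cc([N+](=O)[O-])ccc1NS(C)(=O)=O`: 2510 nM
compound 2, `CCCCCCOc1cc([N+](=O)[O-])ccc1NS(C)(=O)=O`: 2670 nM
compound 3, `CCCCCCCCCOc1cc([N+](=O)[O-])ccc1N(C)S(C)(=O)=O`: 3960 nM

The three values lie close together; all three pairs fall within the scatter, so no order among them is claimed. Compounds 2 and 1 differ in one place, (hydrogen in place of propyl on a saturated chain carbon, three bonds along the chain from an oxygen on an aromatic ring), and this step gave a 1.1-fold lower number from compound 2 to compound 1 (0.03 log units; within the scatter). Compound 3 carries a different core from compound 2; the difference between the two cores is not broken down here.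

Compound 4, `CCCCCCOc1cc([N+](=O)[O-])ccc1N(C)S(C)(=O)=O`, is not yet measured. It differs from compound 3 by hydrogen in place of propyl on a saturated chain carbon, six bonds along the chain from an oxygen on an aromatic ring. Among the compounds with values here, this is the same kind of change as the one from compound 2 to compound 1, but not the same: there the hydrogen enters three bonds along the chain from the oxygen on the aromatic ring, here six bonds along the chain from that oxygen. Within the data shown here, on the one measured instance the chain shortening left the number essentially in place, and the expected step from compound 3 to compound 4 is likewise small, a 1.1-fold lower number from compound 3 to compound 4 (0.05 log units; within the scatter), because a 1.1-fold lower number from compound 2 to compound 1 (0.03 log units; within the scatter) stayed within the scatter. Compound 4 is thus estimated at 3500 nM in this assay, with an expected range from 1800 nM to 7000 nM.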

Compound 4, half-maximal inhibitory concentration: 4490 nM
Beside the measured number, compound 4's estimate is 1.3-fold (0.11 log units) below it; the range from low to high includes it.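

In this assay, hydrogen in place of propyl, six bonds along the chain from the oxygen on the aromatic ring, gave a 1.1-fold higher number from compound 3 to compound 4 (0.05 log units; within the scatter), and the same kind of change on the two cores does not differ: the same change on two cores in this assay, a 1.1-fold lower number (0.03 log units; within the scatter) from compound 2 to compound 1 and a 1.1-fold higher number (0.05 log units; within the scatter) from compound 3 to compound 4, 1.2-fold (0.08 log units) apart, within the scatter of two such steps Methyl in place of hydrogen on the sulfonamide nitrogen gave a 1.7-fold higher number from compound 2 to compound 4 (0.23 log units; within the scatter), and on these compounds neither the chain change nor the change of core moves the number beyond the scatter. Within the data shown here, this agreement rests on only two steps, each within the scatter and each at a different place on the chain, and it shows that the change carried over without a detectable shift, not that a real effect of the change transfers from one core to the other.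

The compounds shown leave open whether an amine or a carboxylic acid in place of the chain would move the number beyond the scatter. Also open, on these data alone, is whether ethyl in place of methyl on the sulfonamide nitrogen would do so.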